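Ester variation on a shared quinolinone core and cytotoxicity

The source may hold more compounds than are shown below. What is called first, only, known or untested is meant among the compounds shown, and "the series" means these compounds.

Compound 1 `CC(C)C(=O)OCCc1c(-c2ccccc2Cl)c2cc(Cl)ccc2[nH]c1=O` gives 62000 nM in an ADME assay on HepG2 2.2.15 cells (Homo sapiens) for cytotoxicity (a lower number here means that less compound is tolerated, a higher number that more compound is tolerated), the lowest of the two plain numbers reported. Compound 2 `N#CCC(=O)OCCc1c(-c2ccccc2Cl)c2cc(Cl)ccc2[nH]c1=O` gives 100000 nM, a change of a 1.6-fold higher number from compound 1 to compound 2 (0.21 log units; within the scatter). Compound 3 `O=C(OCCc1c(-c2ccccc2Cl)c2cc(Cl)ccc2[nH]c1=O)c1cccs1` reaches only a limit of this assay, > 1700000 nM. That limit, (the limit of > 1700000 nM in this assay, at which 1 of the 3 values shown sits), marks the steps of an at least 27-fold higher number from compound 1 to compound 3 (1.43 log units; beyond the scatter) and an at least 17-fold higher number from compound 2 to compound 3 (1.23 log units; beyond the scatter). Compound 4 `O=C(COc1ccccc1)OCCc1c(-c2ccccc2Cl)c2cc(Cl)ccc2[nH]c1=O` differs from compound 1 in that (phenoxymethyl in place of isopropyl on a carbonyl carbon). The change to cyanomethyl left the number within scatter, while the change to thiophen-2-yl raised it beyond it; phenoxymethyl carries an aromatic ring as thiophen-2-yl does, so a rise is expected, though possibly smaller. Compound 4 is estimated at 250000 nM, between 70000 nM and 1200000 nM, a step of a 4.0-fold higher number from compound 1 to compound 4 (0.61 log units; beyond the scatter) expected.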

Compound 4, half-maximal cytotoxic concentration: 81000 nM
Compound 4: middle estimate off by 3.1-fold (0.49 log units), on the high side, and the stated range covers the measured number.
By their numbers in this assay, from the lowest: compounds 1, 4 and 2 (each within the scatter of the next). At a limit, above all of these: compound 3.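

Phenoxymethyl brings an aromatic ring to this carbonyl carbon, yet in this assay replacing isopropyl with it gives a 1.3-fold higher number from compound 1 to compound 4 (0.12 log units; within the scatter), and replacing the cyano of cyanomethyl with phenoxy gives a 1.2-fold lower number from compound 2 to compound 4 (0.09 log units; within the scatter). An aromatic ring at this place is therefore not enough on its own to separate a compound from the others. Compound 3 stands at a limit of the assay, > 1700000 nM, and thiophen-2-yl remains apart from phenoxymethyl, with an at least 20-fold lower number from compound 3 to compound 4 (1.32 log units; beyond the scatter). Still open, on these data alone, is whether a phenyl group on the carbonyl carbon would follow thiophen-2-yl or phenoxymethyl, and where an amine in the chain would fall.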